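The compounds below may be only part of what the source reports. "The series", "measured", "known", "first", "only" and "open" are said of these compounds alone.

In an in vitro ADME assay on microsomes from liver (Homo sapiens) for metabolic stability, in the presence of a further agent that is not named here (on this read-out higher numbers stand for fast clearance and lower numbers for slow clearance), compound 1 (`CC(C)(CO)CNC(=O)c1cc2cc(C#N)ccc2n1Cc1cccc(OC(F)(F)F)c1`) gives 20 mL.min-1.g-1 and compound 2 (`CCOc1ccc(OC(F)(F)F)cc1Cn1c(C(=O)NCC(C)(C)CO)cc2cc(C#N)ccc21`) gives 20 mL.min-1.g-1 on the same read-out, so the two stand level and neither is the better starting point on these numbers. Compound 3 (`CC(O)C1(CNC(=O)c2cc3cc(C#N)ccc3n2Cc2cccc(OC(F)(F)F)c2)CCCC1`) keeps the core of compound 1 and differs from it in one place (a group of 8 heavy atoms (7 carbon, 1 oxygen; one five-membered non-aromatic ring of carbon only) in place of a group of 5 heavy atoms (4 carbon, 1 oxygen; no ring), on a saturated chain carbon bound to an amide-type nitrogen). Going by the values given here, the only measured step (no change at the digits printed from compound 1 to compound 2 (within the scatter)) puts an ethoxy in place of hydrogen on an aromatic carbon, not on a saturated chain carbon bound to an amide-type nitrogen, so it bears on the new change only indirectly. Among the compounds with values here, no measured compound varies the group that leaves here, and the size of this step remains open. Compound 2 shows no large move on gaining a group elsewhere (no change at the digits printed from compound 1 to compound 2 (within the scatter)), so only a modest step is expected in this assay, upward if there is one, for the larger group that enters. The estimated step is a 1.5-fold higher number from compound 1 to compound 3 (0.18 log units; within the scatter) on this read-out, with a wide margin. For compound 3 the estimated clearance is 30 mL.min-1.g-1 (expected range 14 mL.min-1.g-1 to 65 mL.min-1.g-1).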

Compound 3, intrinsic clearance in microsomes: 9 mL.min-1.g-1
Beside the measured number, compound 3's estimate is 3.3-fold (0.52 log units) above it; measured number below the stated range.
By their numbers in this assay, from the lowest: compound 3; then compounds 1 and 2 (each within the scatter of the next).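

In this assay, going by these compounds alone, the saturated chain carbon bound to an amide-type nitrogen is the first place where a change moves the read-out beyond the scatter: the group with one five-membered non-aromatic ring of carbon only, in place of 1-(hydroxymethyl)-1-methylethyl, gives a 2.2-fold lower number from compound 1 to compound 3 (0.35 log units; beyond the scatter), while ethoxy in place of hydrogen on an aromatic carbon gives no change at the digits printed from compound 1 to compound 2 (within the scatter). The larger group thus goes with a lower number at this place, with hydrogen-bond donor and acceptor counts unchanged and no net charge on either group, although this rests on a single pair. Nothing available here accounts for the step.

The pair does not separate the ring itself from the added carbons or from the changed arrangement around the hydroxyl-bearing carbon, and a six-membered carbon ring or an amine-bearing group at this place would test how far the step extends. Also open, going by these compounds, is whether the new group and the ethoxy on an aromatic carbon would behave independently when carried together on the shared core.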